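Thioether branching on a pyrazolopyrimidinone retinal dehydrogenase 2 series

The compounds below may be only part of what the source reports. "The series", "measured", "known", "first", "only" and "open" are said of these compounds alone.

Measured compounds:
compound 1, `Cn1ncc2c(=O)n(-c3ccccc3)c(COc3cccc(F)c3)nc21`, 1770 nM
compound 2, `Cn1ncc2c(=O)n(-c3ccccc3)c(SC(C)(C)c3ccccc3)nc21`, 2200 nM
compound 3, `CC(C)C(Sc1nc2c(cnn2C)c(=O)n1-c1ccccc1)c1ccccc1`, 300 nM

All three were tested in an assay on isolated protein for inhibition of retinal dehydrogenase 2 (Homo sapiens); on this read-out lower numbers stand for stronger inhibition and higher numbers for weaker inhibition. Compound 2 holds the highest number of the three. Its nearest neighbour is compound 1, whose value sits within the scatter of the value of compound 2, so the two cannot be ordered. Compound 3, the most potent of the three, lies well beyond the scatter from compound 2, and its difference from compound 2 is the only clear separation in this set.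

Compound 4, `C[C@@H](Sc1nc2c(cnn2C)c(=O)n1-c1ccccc1)c1ccccc1`, has not yet been measured in this assay. It differs from compound 2 in one place: 1-phenylethyl in place of 1-methyl-1-phenylethyl on a sulfur. For the measured compounds named here, no measured pair isolates exactly this change. Because compound 3, which also carries a 1-phenylethyl-type branch at the sulfur bearing a further alkyl group, gives 300 nM, the account expects compound 4 to move toward stronger inhibition. The step is expected to be modest, about a 2.4-fold lower number from compound 2 to compound 4 (0.39 log units; beyond the scatter), perhaps just beyond the scatter rather than reaching the value of compound 3. The estimate for compound 4 in this assay is 900 nM, expected to fall between 300 nM and 2700 nM.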

Compound 4, half-maximal inhibitory concentration: 40 nM
Compound 4: middle estimate off by 23-fold (1.35 log units), on the high side; the whole stated range lies above it.
By their numbers in this assay, from the lowest: compound 4; then compound 3; then compounds 1 and 2 (each within the scatter of the next).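

For the compounds shown here, compound 2 and compound 4 are the first pair that differ in one place, and the change on the sulfur gives a 55-fold lower number from compound 2 to compound 4 (1.74 log units; beyond the scatter) in this assay. This shows that the substituent on a sulfur whose other neighbour is an aromatic carbon can control potency strongly, since 1-phenylethyl, with 8 heavy atoms and 1 defined stereocentre, replaces 1-methyl-1-phenylethyl, with 9 heavy atoms, while the phenyl ring is kept and the donor, acceptor and charge counts stay the same. No measurement given here accounts for the size of this step.

The compounds shown leave open how much of the step depends on the defined stereocentre, since neither the opposite configuration of the 1-phenylethyl group nor an unbranched benzyl group on the sulfur appears among them. They also leave open whether a fluorine, a methoxy group or a carboxylic acid on the phenyl ring of the 1-phenylethyl group would preserve the value of compound 4 at 40 nM.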